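The source may report more compounds than this note shows. Statements on the series, on what has been measured and on what is new or still open speak of the compounds shown alone.

In an assay for inhibition of histone deacetylase 9 (Homo sapiens), read by fluorescence, with a stated time of 3 h (on this read-out lower numbers stand for an effect already at smaller amounts and higher numbers for an effect only at larger amounts of compound), compound 3 `O=C(/C=C/c1cccc(S(=O)(=O)N2CCN(c3ccccn3)CC2)c1)NO` gives 86 nM. Compound 2 `O=C(/C=C/c1cccc(S(=O)(=O)Nc2cccc(F)c2)c1)NO` gives 109 nM, a number within the scatter of that of compound 3, whereas compound 1 `COc1ccc(NS(=O)(=O)c2cccc(/C=C/C(=O)NO)c2)cc1` gives 26 nM, a lower number beyond the scatter. Compound 4 `COc1ccccc1N1CCN(S(=O)(=O)c2cccc(/C=C/C(=O)NO)c2)CC1` differs from compound 3 by 2-methoxyphenyl in place of pyridin-2-yl on an amine nitrogen in a ring. Within the data shown here, the only measured step, a 4.2-fold higher number from compound 1 to compound 2 (0.62 log units; beyond the scatter), changes the aryl group on the sulfonamide nitrogen and not the group on the amine nitrogen in the ring, so it bears only loosely on this change and offers no direction. Hence no step beyond the scatter is expected for no change at the digits printed from compound 3 to compound 4 (within the scatter). Compound 4 is therefore estimated at 86 nM, with a range from 35 nM to 220 nM.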

Compound 4, concentration for half-maximal effect: 145 nM
Compound 4: middle estimate off by 1.7-fold (0.23 log units), on the low side; the measured number falls inside the stated range.
By their numbers in this assay, from the lowest: compound 1; then compounds 3, 2 and 4 (each within the scatter of the next).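

Among these compounds, this is the first measured change at this position: in this assay, 2-methoxyphenyl in place of pyridin-2-yl on the amine nitrogen in the ring gives a 1.7-fold higher number from compound 3 to compound 4 (0.23 log units; within the scatter). The position therefore accepts a ring of carbon only in place of the ring with one hetero atom, and 8 heavy atoms in place of 6, without a step beyond the scatter. No evidence is available that bears on this result. On these data alone, it remains open whether an unsubstituted phenyl or a pyrimidin-2-yl group on this nitrogen would stay within the scatter. As far as these compounds go, the effect of a carboxylic acid or a longer alkyl chain there is also open.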